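The source may hold more compounds than are shown below. What is called first, only, known or untested is meant among the compounds shown, and "the series" means these compounds.

Working notes on the series. Compound 1 `N#CNC(=N)NCCCCCn1nc(-c2ccccc2)ccc1=O` and compound 2 `C/N=C(\NC#N)NCCCCn1nc(-c2ccccc2)ccc1=O` share the core and differ in the length of the saturated chain and in the terminal guanidine-type group. In a functional assay on the whole organism (stomach) with Rattus norvegicus as the target (a higher number here means that more compound is needed for the effect, a lower number that less compound is needed), compound 1 gives only a limit, > 100 mg/kg. In this assay, among the compounds with values here, compound 2 gives 32.4 mg/kg, the only actual number so far. The remaining entry, that of compound 1, is a limit (the limit of > 100 mg/kg in this assay, at which 1 of the 2 values shown sits). The measured step of an at least 3.0-fold lower number from compound 1 to compound 2 (0.48 log units; beyond the scatter) is beyond the scatter, though its true size is open because compound 1 sits at a limit.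

Compound 3 `N#CNC(=N)NCCCn1nc(-c2ccccc2)ccc1=O` differs from compound 2 by a group of 6 heavy atoms (2 carbon, 4 nitrogen; no ring) in place of a group of 8 heavy atoms (4 carbon, 4 nitrogen; no ring), on a saturated chain carbon, three bonds along the chain from an aromatic nitrogen, so it carries the unsubstituted terminal group of compound 1 on a chain shortened further. Within the data shown here, the only measured step runs the other way, from the unsubstituted group on a longer chain to the methylated group on a shorter one, and gave a lower number. The expectation for compound 3 is therefore a higher dose than compound 2, with a real chance that this assay again reports only a limit. Compound 3 is estimated at 80 mg/kg (range 25 mg/kg to 300 mg/kg), an expected step of a 2.5-fold higher number from compound 2 to compound 3 (0.39 log units; beyond the scatter).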

Compound 3, dose for half-maximal effect: > 100 mg/kg
Compound 3 was reported as a limit (the forecaster's own chance of this, stated with the estimate: 45%); middle value at least 1.2-fold (0.09 log units) from the limit.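

Against compound 2, the group of 6 heavy atoms (2 carbon, 4 nitrogen; no ring) in place of the group of 8 heavy atoms (4 carbon, 4 nitrogen; no ring) gives an at least 3.0-fold higher number from compound 2 to compound 3 (0.48 log units; beyond the scatter), so compound 2 now stands apart from the unsubstituted terminal group on a longer chain and on a shorter one. In this assay, from the compounds shown here alone, compound 3 gives only a limit, and with compound 1 also at a limit, the step between those two cannot be read, so the effect of chain length with the unsubstituted group remains unknown. The series therefore has one actual number, with the other two entries resting at the same limit: the limit of > 100 mg/kg in this assay, at which 2 of the 3 values shown sit.

Both steps from compound 2 change the chain length and the terminal group together, so the compounds shown do not separate the contribution of the methyl group from that of the chain. Going by these compounds, it remains open how the methylated group would read on a longer or shorter chain, and whether an ethyl group on the same nitrogen would give a lower number than compound 2.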